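Amide extension on a shared aminoquinoline core

A few compounds are considered here, and "the series" means these few. Any claim that something is new, unique, unknown or untested is made for them only; others in the source may bear on it.

Measured: compound 1 `CCCc1cc(N)c2cc(NC(=O)c3ccc(C(F)(F)F)cc3)ccc2n1` with 10000 nM; compound 2 `CCCc1cc(N)c2cc(NC(=O)/C=C/c3ccc(Cl)cc3Cl)ccc2n1` with 6.6 nM.

In an assay on isolated protein for displacement of a labelled ligand from melanin-concentrating hormone receptor 1 (Homo sapiens) (on this read-out higher numbers stand for weaker inhibition and lower numbers for stronger inhibition), compound 1 gives 10000 nM, the higher of the two numbers. Compound 2 gives 6.6 nM in this assay, a difference that lies far beyond the scatter, so compound 1 is the weaker binder of the pair.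

Compound 3 `CCCc1cc(N)c2cc(NC(=O)c3ccc(-c4ccc(C(F)(F)F)cc4)cc3)ccc2n1` is not yet measured. It differs from compound 1 in one place: 4-(trifluoromethyl)phenyl in place of trifluoromethyl on an aromatic carbon. The change extends the acyl part of the amide outward, whereas compound 2 reaches further from the amide by a different route. Given the weak number for compound 1 at 10000 nM and the strong one for compound 2 at 6.6 nM, a step toward a lower number is expected from compound 1 to compound 3, estimated at a 20-fold lower number from compound 1 to compound 3 (1.30 log units; beyond the scatter). Compound 3 is expected to give 500 nM in this assay, within 30 nM to 5000 nM.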

Compound 3, half-maximal inhibitory concentration: 4.5 nM
Estimate against measurement, compound 3: 110-fold (2.05 log units) above; measured number outside the range, below it.
By their numbers in this assay, from the lowest: compounds 3 and 2 (each within the scatter of the next); then compound 1.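

For the compounds shown here, the replacement of trifluoromethyl by 4-(trifluoromethyl)phenyl on an aromatic carbon, para to a large group, provides the first single-place comparison: in this assay it gives a 2200-fold lower number from compound 1 to compound 3 (3.35 log units; beyond the scatter). This position therefore accepts an added six-membered aromatic ring, and the read-out is highly sensitive to the group placed there. Nothing measured here bears on why the step is so large.

The compounds shown leave open whether the trifluoromethyl on the added ring is needed, which a plain phenyl, or the same ring carrying a methoxy group or a carboxylic acid, would test. Also open, from the compounds shown here alone, is whether the added ring must be aromatic, a question that a cyclohexyl group in its place would address.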